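Swapping the Phenyl Substituent on an Adenosine Antagonist

The source may report more compounds than this note shows. Statements on the series, on what has been measured and on what is new or still open speak of the compounds shown alone.

Compound 1 `Cn1c(=O)c2nc(-c3ccc(Cl)cc3)[nH]c2n(C)c1=O` and compound 2 `Cc1ccc(-c2nc3c(=O)n(C)c(=O)n(C)c3[nH]2)cc1` share one core and differ only on the outer ring. In an assay on membranes from brain for binding affinity to adenosine receptor A1 (Rattus norvegicus), read by radioligand binding (a lower number here means a stronger inhibitor, a higher number a weaker inhibitor), compound 1 gives 0.8 nM, and in this assay compound 2 gives 0.8 nM, so compound 2 stands level with compound 1; the step of no change at the digits printed from compound 1 to compound 2 (within the scatter) lies within the scatter. Compound 3 `Cn1c(=O)c2nc(-c3ccc([N+](=O)[O-])cc3)[nH]c2n(C)c1=O` arises from compound 2 by nitro in place of methyl on an aromatic carbon. Going by the values given here, only that one step bears on this change, and it was flat, so the step of a 1.9-fold higher number from compound 2 to compound 3 (0.27 log units; within the scatter) is expected to stay small. Compound 3 is estimated at 1.5 nM, between 0.4 nM and 6 nM.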

Compound 3, half-maximal inhibitory concentration: 8 nM
Beside the measured number, compound 3's estimate is 5.3-fold (0.73 log units) below it; the measured number lies above the stated range.
By their numbers in this assay, from the lowest: compounds 1 and 2 (each within the scatter of the next); then compound 3.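

The outer ring's substituent at this position does matter in this assay: the flat step between chloro and methyl did not carry over to nitro, which gives a 10-fold higher number from compound 2 to compound 3 (1.00 log units; beyond the scatter) and a 10-fold higher number from compound 1 to compound 3 (1.00 log units; beyond the scatter). Compound 3 is therefore the weakest of the three, so a group's fit here cannot be judged from the first pair alone. No available evidence explains why nitro stands apart from chloro and methyl. On these data alone, it remains open whether an amine, a carboxylic acid or a methoxy group here would stay level with chloro and methyl or move toward nitro.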